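Adding a Bromophenyl Arm to a Weak Reductase Inhibitor

A few compounds are considered here, and "the series" means these few. Any claim that something is new, unique, unknown or untested is made for them only; others in the source may bear on it.

Compound 1, `COc1ccccc1N1CCN(CCCOc2ccc(C(=O)Nc3ccccc3OCCCC(=O)O)cc2)CC1`: 41000 nM
Compound 2, `COc1ccccc1N1CCN(CCC(Oc2ccc(NC(=O)c3ccccc3OCCCC(=O)O)cc2)c2ccc(C)cc2)CC1`: 440 nM

Of the compounds shown here, two have been measured in an assay on isolated protein for inhibition of steroid 5-alpha-reductase (Rattus norvegicus); a higher number here means a weaker inhibitor, a lower number a stronger inhibitor. Compound 1 stands at the top of the two numbers, giving 41000 nM in this assay, and is thus the weaker of the pair. Among the measured compounds shown here, compound 2 gives 440 nM, a much lower number, but it differs from compound 1 in more than one place, so no single step between them can be read off.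

Compound 3, `COc1ccccc1N1CCN(CCC(Oc2ccc(C(=O)Nc3ccccc3OCCCC(=O)O)cc2)c2ccc(Br)cc2)CC1`, is not yet measured. It differs from compound 1 in one place: 4-bromophenyl in place of hydrogen on a saturated chain carbon bound to an oxygen on an aromatic ring and a saturated chain carbon. Compound 2 carries a related aryl group on the same chain carbon, and its much lower value against compound 1 suggests that an aryl group at this position goes with stronger inhibition, although the other differences in compound 2 keep this from being a clean comparison.

A step well beyond the scatter, towards a lower number, is expected in this assay, a 27-fold lower number from compound 1 to compound 3 (1.44 log units; beyond the scatter). Compound 3 is therefore estimated at 1500 nM, with a range from 300 nM to 8000 nM.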

Compound 3, half-maximal inhibitory concentration: 210 nM
Compound 3: the middle estimate sits 7.1-fold (0.85 log units) above what was measured, and the stated range ends above it.
By their numbers in this assay, from the lowest: compound 3; then compound 2; then compound 1.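

In this assay, 4-bromophenyl in place of hydrogen on a saturated chain carbon bound to an oxygen on an aromatic ring and a saturated chain carbon goes with a step beyond the usual scatter (a 200-fold lower number from compound 1 to compound 3 (2.29 log units; beyond the scatter)) and so marks this carbon as a place where one change moves the number a long way. Among the compounds shown here, compound 2 also carries an aryl group on this carbon, but it differs from compound 1 in more than one place, so only this single change ties a large drop in the number to the position itself and shows that a group as large as 4-bromophenyl can sit there with a much stronger inhibitor as the result. Nothing measured here explains why this change has so large an effect.

For the compounds shown here, with only this one pair to read, it remains open whether the step belongs to the aromatic ring or to its bromine, a question that a plain phenyl group at the same carbon would help to settle. From the compounds shown here alone, it also remains open how a small methyl group or a 4-chlorophenyl group at this carbon would compare with hydrogen and 4-bromophenyl.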